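The compounds below may be only part of what the source reports. "The series", "measured", "known", "first", "only" and "open" are said of these compounds alone.

Among the measured compounds shown here, in a functional assay on MCF7 cells (Homo sapiens) for cytotoxicity, read by MTT assay, with a stated time of 72 h (on this read-out higher numbers stand for weaker inhibition and lower numbers for stronger inhibition), compound 1 `Cc1oc2ncnc(Nc3cccc(Br)c3)c2c1C(=O)O` gives 68000 nM, the only true number so far. For compound 2 `CCOC(=O)c1c(C)oc2ncnc(Nc3ccc(OCc4ccccc4)cc3)c12`, the result of > 1000000 nM is a limit and not a number. Compound 3 `Cc1oc2ncnc(Nc3cccc(Br)c3)c2c1CO` keeps the core of compound 1 but carries hydroxymethyl in place of carboxy on an aromatic carbon. For the measured compounds named here, no measured pair shows what this swap does, so only a moderate step towards stronger inhibition is expected in this assay, and the direction is uncertain. The expected change is a 1.9-fold lower number from compound 1 to compound 3 (0.29 log units; within the scatter). Compound 3 is estimated at 35000 nM, with an expected range of 9000 nM to 130000 nM.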

Compound 3, half-maximal inhibitory concentration: 11000 nM
Compound 3: middle estimate off by 3.2-fold (0.50 log units), on the high side; the range from low to high includes it.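

In this assay, hydroxymethyl in place of carboxy on an aromatic carbon of the five-membered ring gives a 6.2-fold lower number from compound 1 to compound 3 (0.79 log units; beyond the scatter), so this place on the shared core does respond to what it carries. Both groups hold 1 hydrogen-bond donor and 1 hydrogen-bond acceptor, so these counts do not separate them. Nothing measured here explains why the number falls. On these data alone, whether an amine or a longer chain at this place would give a lower or a higher number remains open.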